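The compounds below may be only part of what the source reports. "The series", "measured", "known", "first", "only" and "open" are said of these compounds alone.

Three compounds of this series have been taken through a functional assay on HCT-116 cells (Homo sapiens) for cytotoxicity, read by MTT assay, with a stated time of 72 h (on this read-out higher numbers stand for weaker inhibition and lower numbers for stronger inhibition), so far, with mixed results. Compound 1 `C[C@@H](CO)Nc1nc(C(=O)NCc2ccc(F)cc2)c(O)c2ncccc12` has no result in this assay ("not determined" (no result reported)). Compound 2 `NCCCNc1c(C(=O)NCc2ccc(F)cc2)ncc2cccnc12` reached only a limit of the assay rather than a number: in this assay compound 2 gives > 10000 nM. Compound 3 `N[C@H]1CC[C@H](Nc2c(C(=O)NCc3cccc(C(F)(F)F)c3)nc(Br)c3cccnc23)CC1` likewise carries no number in this assay ("not determined" (no result reported)). So compound 3 stands without a value of its own, and what surrounds it is thin: one entry without a result and one sitting at the limit, as the evidence shows (the limit of > 10000 nM in this assay, at which 1 of the 3 values shown sits).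

Compound 4 `N[C@H]1CC[C@H](Nc2c(C(=O)NCc3ccccc3)nc(Br)c3cccnc23)CC1` is yet to be measured. It differs from compound 3 in one place (hydrogen in place of trifluoromethyl on an aromatic carbon). Within the data shown here, no measured pair of compounds differing in a single place exists here, so the size of this step in this assay cannot be read from the data; the expectation is a step of no more than the usual scatter, in no set direction. Compound 4 is therefore estimated to fall around 8000 nM, within a range from 1000 nM to 50000 nM, with a real chance that this assay reports only a limit.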

Compound 4, half-maximal inhibitory concentration: 7000 nM
Compound 4: the middle estimate sits 1.1-fold (0.06 log units) above what was measured; the range from low to high includes it.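

Among these compounds, compound 3 carries no number in this assay, so no step to compound 4, at 7000 nM, can be read. The compounds shown leave open whether going from 3-(trifluoromethyl)benzyl to benzyl shifts the result in this assay at all.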